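This account rests on a few compounds, and the source may have more. Where it says the series, first, only, none or still open, it means among the compounds named here.

Of the compounds shown here, three built on one shared core have been measured in a functional assay for inhibition of sodium/hydrogen exchanger (Oryctolagus cuniculus); on this read-out higher numbers stand for weaker inhibition and lower numbers for stronger inhibition. Compound 1 `Cc1cc(-c2ccc(Cl)cc2Cl)c(S(C)(=O)=O)cc1C(=O)N=C(N)N` gives 42 nM. Compound 2 `CSc1cc(C)c(C(=O)N=C(N)N)cc1S(C)(=O)=O` gives 6 nM. Compound 3 `Cc1cc(Oc2cccc(Cl)c2)c(S(C)(=O)=O)cc1C(=O)N=C(N)N` gives 21 nM, the second highest of the three numbers; its gap to compound 1 lies within the scatter, while its gap to compound 2 lies beyond it.

Compound 4 `Cc1cc(N2CCCCC2)c(S(C)(=O)=O)cc1C(=O)N=C(N)N` is not yet measured. It differs from compound 3 in one place: piperidin-1-yl in place of 3-chlorophenoxy on an aromatic carbon. The measured steps that alter this same position are a 7.0-fold lower number from compound 1 to compound 2 (0.85 log units; beyond the scatter), a 2.0-fold lower number from compound 1 to compound 3 (0.30 log units; within the scatter) and a 3.5-fold higher number from compound 2 to compound 3 (0.54 log units; beyond the scatter). Methylsulfanyl goes with the lowest number, and the two groups that carry a chlorinated aromatic ring stand close to each other. Going by the values given here, no measured compound carries piperidin-1-yl or any group like it at this position, so the expectation can rest only on the span these three numbers cover. Compound 4 is therefore expected to give about 12 nM, in a range from 4 nM to 40 nM. The expected step is a 1.8-fold lower number from compound 3 to compound 4 (0.24 log units; within the scatter).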

Compound 4, half-maximal inhibitory concentration: 21 nM
Compound 4: middle estimate off by 1.8-fold (0.24 log units), on the low side; measured number inside the range.
By their numbers in this assay, from the lowest: compound 2; then compounds 3, 4 and 1 (each within the scatter of the next).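

In this assay, the step of no change at the digits printed from compound 3 to compound 4 (within the scatter) shows that a chlorinated aromatic ring is not needed for a number at this level: piperidin-1-yl, a non-aromatic ring without chlorine, reads the same as 3-chlorophenoxy. Going by these compounds alone, the step of a 2.0-fold lower number from compound 1 to compound 4 (0.30 log units; within the scatter) likewise stays within the scatter, while a 3.5-fold higher number from compound 2 to compound 4 (0.54 log units; beyond the scatter) leaves methylsulfanyl as the only group here set apart from the other three. Nothing shown here explains why these groups group this way.

Methylsulfanyl is also the only group shown that carries no ring, so whether that absence goes with its lower number stays open. Also open, from the compounds shown here alone, is what a smaller open amine such as dimethylamino, or a ring with a second hetero atom such as morpholin-4-yl, would give at this position.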